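A change of aryl group on the shared core

The source may hold more compounds than are shown below. What is called first, only, known or untested is meant among the compounds shown, and "the series" means these compounds.

- compound 1 `Cc1ccc(C)c(/C=C(\C(=O)c2ccc(Cl)cc2)S(=O)(=O)c2ccc(Br)cc2)c1` gives 1000 nM
- compound 2 `COc1ccc(/C=C(\C(=O)c2ccc(Cl)cc2)S(=O)(=O)c2ccc(C)cc2)cc1O` gives 1000 nM

In a functional assay on DU-145 cells (Homo sapiens) for inhibition, read by trypan blue exclusion, with a stated time of 96 h (a lower number here means a stronger inhibitor of growth, a higher number a weaker inhibitor of growth), compound 2 gives 1000 nM and stands level with compound 1, within the scatter. Compound 3 `Cc1ccc(S(=O)(=O)/C(=C/c2cc(C)ccc2C)C(=O)c2ccc(Cl)cc2)cc1` is still unmeasured. It differs from compound 2 2,5-dimethylphenyl in place of 3-hydroxy-4-methoxyphenyl on a double-bonded chain carbon bound to a double-bonded chain carbon by carrying 2,5-dimethylphenyl in place of 3-hydroxy-4-methoxyphenyl on a double-bonded chain carbon bound to a double-bonded chain carbon. Going by the values given here, no measured step speaks to this change. Among the compounds with values here, compound 1 at 1000 nM and compound 2 at 1000 nM are the only guide, and no shift beyond the scatter is expected in this assay here. The expected move is no change at the digits printed from compound 2 to compound 3 (within the scatter) and no more. Compound 3 is estimated at 1000 nM (expected range 400 nM to 2500 nM).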

Compound 3, concentration for 50% growth inhibition: 1000 nM
Compound 3: middle estimate and measured number agree at the digits printed; the measured number falls inside the stated range.
By their numbers in this assay, from the lowest: compounds 1, 2 and 3 (each within the scatter of the next).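

In this assay, 2,5-dimethylphenyl in place of 3-hydroxy-4-methoxyphenyl on a double-bonded chain carbon bound to a double-bonded chain carbon gives no change at the digits printed from compound 2 to compound 3 (within the scatter), so losing the group's hydrogen-bond donor and two acceptors leaves the reading level. Methyl in place of bromo on an aromatic carbon gives no change at the digits printed from compound 1 to compound 3 (within the scatter), the first single-place comparison on that other aryl group. No supporting evidence bears on these results. On these data alone, whether an amine or a carboxylic acid in place of the 2,5-dimethylphenyl would move the number stays open.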